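Working notes: from chloro to methyl

This account rests on a few compounds, and the source may have more. Where it says the series, first, only, none or still open, it means among the compounds named here.

Measured in an ADME assay on WI-38 cells (Homo sapiens) for cytotoxicity, read by MTT assay, with a stated time of 72 h; a lower number here means a stronger inhibitor, a higher number a weaker inhibitor:
- Compound 1 `O=C(CCc1cccc2c1B(O)OC2)Nc1ccccc1`: 30000 nM
- Compound 2 `O=C(CCc1cccc2c1B(O)OC2)Nc1ccc(Cl)cc1`: > 100000 nM

Compound 2 reads > 100000 nM, which is a limit of the assay and not a number. Compound 3 `Cc1ccc(NC(=O)CCc2cccc3c2B(O)OC3)cc1` differs from compound 2 by methyl in place of chloro on an aromatic carbon, with methyl in place of chloro on an aromatic carbon, para to a large group. Going by the values given here, the one measured step bearing on this is an at least 3.3-fold higher number from compound 1 to compound 2 (0.52 log units; beyond the scatter). Among the compounds with values here, no step to methyl has been measured, so a modest step to a lower number is expected in this assay, though another limit reading remains possible. The estimated step is an at least 2.0-fold lower number from compound 2 to compound 3 (0.30 log units; that floor lies within the scatter). For compound 3 the estimate is 50000 nM, with an expected range of 20000 nM to 100000 nM.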

Compound 3, half-maximal inhibitory concentration: > 100000 nM
Compound 3: no number, only a limit (the forecaster's own chance of this, stated with the estimate: 35%); middle value at least 2.0-fold (0.30 log units) away from the limit.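

In this assay, methyl on the aromatic carbon para to a large group behaves as chloro does there, so the rise is not specific to chloro: an at least 3.3-fold higher number from compound 1 to compound 3 (0.52 log units; beyond the scatter) sits alongside an at least 3.3-fold higher number from compound 1 to compound 2 (0.52 log units; beyond the scatter). Compound 2 and compound 3 both read as limits of the assay, so the step between them cannot be read and chloro and methyl cannot be ranked: the limit of > 100000 nM in this assay, at which 2 of the 3 values shown sit.

Open, from the compounds shown here alone, is whether an amine or a carboxylic acid on this carbon would return a reading with a number. Also open, going by these compounds, is whether any replacement of hydrogen here leaves the reading near that of compound 1.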